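A few compounds are considered here, and "the series" means these few. Any claim that something is new, unique, unknown or untested is made for them only; others in the source may bear on it.

Measured in an ADME assay on THP-1 cells (Homo sapiens) for cytotoxicity, read by MTT assay, with a stated time of 72 h (a lower number here means that less compound is needed, a higher number that more compound is needed for the effect), each entry a limit of the assay and not a number:
compound 1 `CN(C)c1ccc(-c2ccc3[nH]c(=O)nc(-c4ccccc4)c3c2)cn1`: > 50000 nM
compound 2 `N#Cc1ccc(-c2ccc3[nH]c(=O)nc(-c4ccccc4)c3c2)cc1`: > 50000 nM
compound 3 `O=c1nc(-c2ccccc2)c2ccc(-c3cncnc3)cc2[nH]1`: > 50000 nM

Compound 2 has no number, only its limit of > 50000 nM. Going by the values given here, no measured step between single changes exists. Compound 4 `CN1CCN(c2ccc3[nH]c(=O)nc(-c4ccccc4)c3c2)CC1` differs from compound 2 by 4-methylpiperazin-1-yl in place of 4-cyanophenyl on an aromatic carbon. In this assay no change beyond the scatter is expected, and the expectation rests on (the limit of > 50000 nM in this assay, at which 3 of the 3 values shown sit). Should a number appear at all, it is expected on the lower side. The estimated a number no higher from compound 2 to compound 4 (the limit leaves the size open) stays within the scatter. For compound 4 the expected value is 50000 nM, with an estimated range of 20000 nM to 80000 nM.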

Compound 4, half-maximal effective concentration: > 50000 nM
Compound 4: no number, only a limit; the forecaster's own chance of this, stated with the estimate: 70%; the middle value sits exactly at the limit.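

Going by these compounds alone, no step between compound 2 and compound 4 can be read in this assay, as both entries are limits of the assay and not numbers. The compounds shown leave open what numerical value any of them would have, and which change on the shared core would give one.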